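A few compounds are considered here, and "the series" means these few. Any claim that something is new, unique, unknown or untested is made for them only; others in the source may bear on it.

In a functional assay on BaF3 cells (Mus musculus) for antiproliferative activity, read by CCK-8 assay and cell counting, with a stated time of 76 h (a lower number here means a stronger inhibitor, a higher number a weaker inhibitor), compound 3 `COc1cc2nccc(Oc3ccc(Nc4nn(C)cc4C(=O)NCC(C)C)cc3)c2cc1C(N)=O` gives > 10000 nM, which is a limit and not a number. Compound 1 `COc1cc2nccc(Oc3ccc(Nc4nn(C)cc4C(=O)NCc4ccccc4)cc3)c2cc1C(N)=O` gives > 10000 nM, which is also a limit. Both sit at the limit of > 10000 nM in this assay, at which 2 of the 3 values shown sit. Compound 2 `COc1cc2nccc(Oc3ccc(Nc4nn(C)cc4C(=O)N4CCCCC4)cc3)c2cc1C(N)=O` gives an actual number, 5650 nM.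

Compound 4 `COc1cc2nccc(Oc3ccc(Nc4nn(C)cc4C(=O)NOCc4ccccc4)cc3)c2cc1C(N)=O` carries benzyloxy in place of isobutyl on an amide-type nitrogen. The closest measured comparison is a step that the two limits leave unreadable from compound 1 to compound 3. The other two comparisons are an at least 1.7-fold lower number from compound 1 to compound 2 (0.24 log units; that floor lies within the scatter) and an at least 1.7-fold higher number from compound 2 to compound 3 (0.24 log units; that floor lies within the scatter), and neither shows a change beyond the scatter. No step beyond the scatter is therefore expected in this assay, and the expected change is a step that the limit leaves unreadable from compound 3 to compound 4. For compound 4 the estimated value is 12000 nM, with an expected range from 5000 nM to 30000 nM.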

Compound 4, half-maximal inhibitory concentration: > 10000 nM
Compound 4 ended at the assay's limit; the forecaster's own chance of this, stated with the estimate: 75%; the middle value lies beyond the limit too.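

In this assay compound 4 ends at a limit and not a number, so its steps from compound 3 and from compound 1 cannot be read. On this amide-type nitrogen, benzyloxy, like benzyl and isobutyl, gives no actual number, and only compound 2, with piperidin-1-yl, goes against that pattern: the limit of > 10000 nM in this assay, at which 3 of the 4 values shown sit. Among the compounds shown here, the one readable comparison is an at least 1.7-fold higher number from compound 2 to compound 4 (0.24 log units; that floor lies within the scatter). Still open, on these data alone, is whether any group on this carbonyl carbon brings a value far below the limit, such as a morpholine ring or a dimethylamino group in place of piperidin-1-yl.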